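This account rests on a few compounds, and the source may have more. Where it says the series, first, only, none or still open, it means among the compounds named here.

Measured so far:
Compound 1, `O=C(CN1CCN(c2ccccc2Cl)CC1)N1CCN(c2nnc(-c3ccccc3)c(-c3ccccc3)n2)CC1`: 263000 nM
Compound 2, `O=C(CN1CCN(c2cccc(Cl)c2)CC1)N1CCN(c2nnc(-c3ccccc3)c(-c3ccccc3)n2)CC1`: 56300 nM

Both numbers come from a functional assay on MCF7 cells (Homo sapiens) for cytotoxicity, read by MTT assay, with a stated time of 24 h; on this read-out lower numbers stand for stronger inhibition and higher numbers for weaker inhibition. Compound 2 gives the lowest of the two numbers; its nearest neighbour is compound 1, and the step of a 4.7-fold lower number from compound 1 to compound 2 (0.67 log units; beyond the scatter) lies beyond the scatter. Compound 3, `O=C(CN1CCN(c2ccc(Cl)cc2)CC1)N1CCN(c2nnc(-c3ccccc3)c(-c3ccccc3)n2)CC1`, is not yet measured. It differs from compound 2 in one place: 4-chlorophenyl in place of 3-chlorophenyl on an amine nitrogen in a ring. Within the data shown here, the only measured step that bears on this change, a 4.7-fold lower number from compound 1 to compound 2 (0.67 log units; beyond the scatter), also exchanged one chlorophenyl for another on an amine nitrogen in a ring, and it was modest. That step does not tell which way a move to 4-chlorophenyl will go, so the direction is open, and a step no larger than the scatter is the working expectation. Compound 3 is estimated at 45000 nM, with a range from 15000 nM to 150000 nM. The step from compound 2 to compound 3 is expected to be a 1.3-fold lower number from compound 2 to compound 3 (0.10 log units; within the scatter).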

Compound 3, half-maximal inhibitory concentration: 56300 nM
For compound 3 the middle estimate is 1.3-fold (0.10 log units) below the measured one; the range from low to high includes it.
By their numbers in this assay, from the lowest: compounds 2 and 3 (each within the scatter of the next); then compound 1.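

In this assay, 4-chlorophenyl in place of 3-chlorophenyl on the amine nitrogen in the ring leaves the number unchanged (no change at the digits printed from compound 2 to compound 3 (within the scatter)), so these two chlorophenyl groups cannot be told apart at this position. The step from 2-chlorophenyl now has a second reading (a 4.7-fold lower number from compound 1 to compound 3 (0.67 log units; beyond the scatter)) that matches the first (a 4.7-fold lower number from compound 1 to compound 2 (0.67 log units; beyond the scatter)), which leaves compound 1 as the only one of the three set apart beyond the scatter. The data on hand offer no explanation for this pattern.

The compounds shown leave open whether chlorine matters at all on this ring, as opposed to a plain phenyl, a 4-fluorophenyl or a 4-methoxyphenyl. They also leave open how a pyridyl group would compare with these chlorophenyl groups on the same nitrogen.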